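Notes on the step from compound 3 to compound 4

This account rests on a few compounds, and the source may have more. Where it says the series, first, only, none or still open, it means among the compounds named here.

compound 1 `Cc1cc(=O)c2c(O)cc(OCc3ccccc3)c([C@H]3CCN(C)C[C@H]3O)c2o1` gives 18%
compound 2 `Cc1cc(=O)c2c(O)cc(OCc3ccc(Br)cc3)c([C@H]3CCN(C)C[C@H]3O)c2o1` gives 13%
compound 3 `Cc1cc(=O)c2c(O)cc(OCc3ccccc3Br)c([C@H]3CCN(C)C[C@H]3O)c2o1` gives 35%

All three values come from a functional assay on Caco-2 cells (Homo sapiens) for inhibition, read by MTT assay, with a stated time of 48 h, tested at 10 uM (a lower number here means less inhibition of growth, a higher number more inhibition of growth at the concentration tested), and compound 3 stands highest of the three, clear of both others beyond the scatter. Compound 4 `Cc1cc(=O)c2c(O)cc(OCc3ccco3)c([C@H]3CCN(C)C[C@H]3O)c2o1` has not been measured. It carries furan-2-yl in place of 2-bromophenyl on a saturated chain carbon bound to an oxygen on an aromatic ring, so the bromo is lost. Going by the values given here, no measured compound holds a furan-2-yl group and the evidence is therefore indirect. The 2-bromophenyl group gives a number 17 percentage points higher from compound 1 to compound 3 (beyond the scatter) as its step, whereas the 4-bromophenyl group gives a number 5 percentage points lower from compound 1 to compound 2 (within the scatter) as its own. Exchanging these two groups gives a number 22 percentage points higher from compound 2 to compound 3 (beyond the scatter) in turn. The gain of compound 3 thus appears only with 2-bromophenyl. Without a bromo, compound 1 gives 18% as the nearest reference, so a modest fall is expected in this assay for the new group. The expected change is a number 15 percentage points lower from compound 3 to compound 4 (beyond the scatter) on this reading. Compound 4 is estimated at 20% with an expected range from 7% to 36% in this read-out.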

Compound 4, percent growth inhibition at one concentration: 17%
The estimate for compound 4 lay 3 percentage points above the measured number, and the stated range covers the measured number.
By their numbers in this assay, from the lowest: compounds 2, 4 and 1 (each within the scatter of the next); then compound 3.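

In this assay, the furan-2-yl group on a saturated chain carbon bound to an oxygen on an aromatic ring does not keep the level reached with 2-bromophenyl, giving a number 18 percentage points lower from compound 3 to compound 4 (beyond the scatter). Furan-2-yl also sits with the other two groups, giving a number 1 percentage points lower from compound 1 to compound 4 (within the scatter) and a number 4 percentage points higher from compound 2 to compound 4 (within the scatter), so among the four groups at this place, only 2-bromophenyl stands apart, and a five-membered aromatic ring with 1 hetero atom gives no gain here. Nothing available explains why 2-bromophenyl alone stands apart.

The compounds shown leave open whether the gain of compound 3 depends on the bromo itself, which a 2-chlorophenyl or 2-methylphenyl group at this place would test. They also leave open whether a saturated cyclohexyl group would fall with compound 1 and compound 4.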